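Removing the methoxy from the amino side chain

The source may hold more compounds than are shown below. What is called first, only, known or untested is meant among the compounds shown, and "the series" means these compounds.

Four analogues share one core. Compound 1 `CCCN(CCC)c1cc(C)nc2c(-c3ccc(N(C)C)nc3)c(C)nn12` gives 4.2 nM in an assay on CHO cells for binding affinity to corticotropin-releasing factor receptor 1 (Homo sapiens); a higher number here means a weaker inhibitor, a lower number a stronger inhibitor. Compound 2 `CCC(CC)Nc1cc(C)nc2c(-c3cnc(N(C)C)cc3C)c(C)nn12` gives 9.4 nM in this assay. Compound 3 `CCC(COC)Nc1cc(C)nc2c(-c3cnc(N(C)C)cc3C)c(C)nn12` gives 260 nM in this assay, the highest number among the three measured compounds, lying beyond the scatter from compound 2 and from compound 1. Within the data shown here, the only single-point step among them, a 28-fold higher number from compound 2 to compound 3 (1.44 log units; beyond the scatter), shows the methoxy on the chain carrying the whole rise. Compound 4 `CCCN(CC1CC1)c1cc(C)nc2c(-c3cnc(N(C)C)cc3C)c(C)nn12` is the next entry, and its change is (cyclopropylmethyl)(propyl)amino in place of (1-(methoxymethyl)propyl)amino on an aromatic carbon. That change removes the methoxy as well as the hydrogen on the nitrogen. The step from compound 2 to compound 3 bears on it directly, read backwards: taking the methoxy away is expected to give back a large drop of similar size. Without a methoxy on the chain, compound 1 gives 4.2 nM, and likewise compound 2 gives 9.4 nM. A number in that region is expected for compound 4. The estimate for compound 4 is 7 nM, with a range from 2.5 nM to 25 nM, meaning an expected step of a 37-fold lower number from compound 3 to compound 4 (1.57 log units; beyond the scatter).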

Compound 4, inhibition constant: 2.6 nM
Beside the measured number, compound 4's estimate is 2.7-fold (0.43 log units) above it; low and high end bracket the measured number.
By their numbers in this assay, from the lowest: compounds 4 and 1 (each within the scatter of the next); then compound 2; then compound 3.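

In this assay, (cyclopropylmethyl)(propyl)amino in place of (1-(methoxymethyl)propyl)amino on this aromatic carbon gives a 100-fold lower number from compound 3 to compound 4 (2.00 log units; beyond the scatter), so this position can also carry a substituent with no hydrogen on the nitrogen and no oxygen on the chain. The comparison without the methoxy on either side gives a 3.6-fold lower number from compound 2 to compound 4 (0.56 log units; beyond the scatter), which shows that losing the hydrogen-bond donor does not raise the number here, although this step cannot separate the loss of that hydrogen from the entry of the three-membered ring. No measurement bears on why these side chains differ.

The compounds shown leave open whether the cyclopropylmethyl group itself contributes, which a butyl chain in its place would test. Going by these compounds, it also remains open whether a methoxy on one chain of a disubstituted amino group, as in a (2-methoxyethyl)(propyl)amino group, would bring a rise like that seen on the secondary amine.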